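A Nitro Swap on the Thiosemicarbazone Series

A few compounds are considered here, and "the series" means these few. Any claim that something is new, unique, unknown or untested is made for them only; others in the source may bear on it.

Compound 1 `CCc1ccc(NC(=S)N/N=C\c2ccnc3ccccc23)cc1`: 820 nM
Compound 2 `Fc1ccc(NC(=S)N/N=C\c2ccnc3ccccc23)cc1`: 1100 nM

In a functional assay on MCF7 cells (Homo sapiens) for cytotoxicity, read by MTT assay, with a stated time of 48 h (a higher number here means a weaker inhibitor, a lower number a stronger inhibitor), compound 2 gives 1100 nM, which lies within the scatter of compound 1 at 820 nM. The two numbers therefore do not separate these compounds.

Compound 3 `O=[N+]([O-])c1ccc(NC(=S)N/N=C\c2ccnc3ccccc23)cc1` has nitro in place of fluoro on an aromatic carbon, para to a large group: nitro in place of fluoro on an aromatic carbon. For the measured compounds named here, only one measured step bears on this change, a 1.3-fold higher number from compound 1 to compound 2 (0.13 log units; within the scatter), which exchanged ethyl for fluoro and stayed within the scatter. Going by the values given here, no measured compound carries nitro, so the evidence for this group is thin. No step beyond the scatter is therefore expected in this assay, and no firm direction can be given. The expected step is a 1.2-fold lower number from compound 2 to compound 3 (0.09 log units; within the scatter). Compound 3 is estimated at 900 nM, with an expected range of 300 nM to 2700 nM.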

Compound 3, half-maximal inhibitory concentration: 810 nM
For compound 3 the middle estimate is 1.1-fold (0.05 log units) above the measured one; the range from low to high includes it.
By their numbers in this assay, from the lowest: compounds 3, 1 and 2 (each within the scatter of the next).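

In this assay, for the compounds shown here, the place on the aromatic ring para to a large group now carries ethyl, fluoro and nitro, and nitro is the first of these with hydrogen-bond acceptors. Nitro in place of fluoro gives a 1.4-fold lower number from compound 2 to compound 3 (0.13 log units; within the scatter) and nitro in place of ethyl gives a 1.0-fold lower number from compound 1 to compound 3 (0.01 log units; within the scatter), so neither exchange separates the compounds, and these three groups give no order at this place. No measurement at hand offers an explanation for this lack of separation.

From the compounds shown here alone, whether an amine, a carboxylic acid or a longer chain at this place would give a step beyond the scatter remains open. Also open, going by these compounds, is whether a change elsewhere on the shared core would separate compounds where these exchanges did not.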